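The source may hold more compounds than are shown below. What is called first, only, known or untested is meant among the compounds shown, and "the series" means these compounds.

Measured so far:
Compound 1, `O=C(CSc1nc(Nc2ccccc2)c2ccccc2n1)Nc1ccccc1Cl`, gives 9610 nM.
Compound 2, `O=C(CSc1nc(Nc2ccccc2)c2ccccc2n1)Nc1ccccc1Br`, gives 10300 nM.
Compound 3, `C=CC(=O)Nc1cccc(NC(=O)CSc2nc(Nc3cccc(Cl)c3)c3ccccc3n2)c1`, gives 9460 nM.

All three numbers come from a functional assay on NCI-H1975 cells (Homo sapiens) for inhibition, read by MTT assay, with a stated time of 72 h; a higher number here means a weaker inhibitor, a lower number a stronger inhibitor. The change from compound 1 to compound 2 is bromo in place of chloro on an aromatic carbon, and it moved the number by a 1.1-fold higher number from compound 1 to compound 2 (0.03 log units; within the scatter). Compound 4, `C=CC(=O)Nc1cccc(NC(=O)CSc2nc(Nc3cccc(Br)c3)c3ccccc3n2)c1`, carries the same kind of change against compound 3: bromo in place of chloro on an aromatic carbon. The place differs in its surroundings, in compound 1 ortho to a large group, in compound 3 meta to a large group. How the core of compound 3 differs from that of compound 1 is not broken down here; the two values lie within the scatter of each other. Since the earlier step stayed within the scatter, compound 4 is expected to sit near compound 3, with an estimated step of a 1.1-fold higher number from compound 3 to compound 4 (0.02 log units; within the scatter). The estimate for compound 4 is 10000 nM, between 5000 nM and 20000 nM.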

Compound 4, half-maximal inhibitory concentration: 12100 nM
The estimate for compound 4 lay 1.2-fold (0.08 log units) below the measured number; measured number inside the range.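

In this assay, bromo in place of chloro on an aromatic carbon gave a 1.3-fold higher number from compound 3 to compound 4 (0.11 log units; within the scatter), so chloro and bromo cannot be told apart on this core. Set beside the earlier step, the same change shows no difference between the two cores: the same change on two cores in this assay, a 1.1-fold higher number (0.03 log units; within the scatter) from compound 1 to compound 2 and a 1.3-fold higher number (0.11 log units; within the scatter) from compound 3 to compound 4, 1.2-fold (0.08 log units) apart, within the scatter of two such steps. Within the data shown here, this shows that the change left the number within the scatter on both cores, but with only two pairs it does not show that this would hold on any other core, or that the same change would stay as small at other places.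

The compounds shown leave open what fluoro, a methoxy group or an amine would do in place of the halogen. On these data alone, whether any such group would move the number beyond the scatter also remains open.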